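Chloro for fluoro on the urea aryl ring

The source may hold more compounds than are shown below. What is called first, only, known or untested is meant among the compounds shown, and "the series" means these compounds.

Measured in a functional assay on GBM1 cells (Homo sapiens) for antiproliferative activity, read by WST assay, with a stated time of 72 h; a higher number here means a weaker inhibitor, a lower number a stronger inhibitor:
compound 1 `O=C(Nc1cccc(F)c1)Nc1cc2ncncc2cc1OCc1cccc(Cl)c1` gives 3700 nM
compound 2 `O=C(Nc1cccc(F)c1)Nc1cc2ncncc2cc1OCc1ccccc1Cl` gives 4000 nM
compound 3 `O=C(Nc1cc2ncncc2cc1OCc1ccc(F)cc1)Nc1cccc2ccccc12` gives 8100 nM

Going by the values given here, compound 1 and compound 2 sit within the scatter of each other, so neither can be set above the other; the only single-point step among the measured compounds, a 1.1-fold higher number from compound 1 to compound 2 (0.03 log units; within the scatter), is within the scatter. Compound 3 differs from compound 1 in two places at once and its value lies beyond the scatter from compound 1, so the two values give no single structural reading.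

Compound 4 `O=C(Nc1cccc(Cl)c1)Nc1cc2ncncc2cc1OCc1cccc(Cl)c1` differs from compound 1 by chloro in place of fluoro on an aromatic carbon. Among the compounds with values here, no measured step touches this position: the one step available moves a chloro around the benzyl ring, and that step was within the scatter. Nothing in the three measured compounds points to either direction for a change on the urea aryl ring, so no step beyond the scatter is expected in this assay, and the expected step of a 1.2-fold lower number from compound 1 to compound 4 (0.09 log units; within the scatter) is small. For compound 4 in this assay a value near 3000 nM is therefore estimated, with the range 1200 nM to 7500 nM allowing for the scatter and for the unmeasured position.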

Compound 4, half-maximal inhibitory concentration: 3300 nM
For compound 4 the middle estimate is 1.1-fold (0.04 log units) below the measured one, within the range that was stated.
By their numbers in this assay, from the lowest: compounds 4, 1 and 2 (each within the scatter of the next); then compound 3.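

In this assay the urea aryl ring now has its first readable single-point step: 3-chlorophenyl in place of 3-fluorophenyl gives a 1.1-fold lower number from compound 1 to compound 4 (0.05 log units; within the scatter) and lies within the scatter. At this place, on an aromatic carbon meta to a large group, the exchange of fluoro for chloro therefore gives no separable difference, which the earlier step on the benzyl ring could not show because it did not touch this ring. No supporting measurement is available to explain this result.

Going by these compounds, whether a group other than a halogen on this ring, such as methoxy, trifluoromethyl, an amine or a carboxylic acid, would give a step beyond the scatter remains open, as does the effect of a halogen at another place on the ring. Compound 3 differs from compound 1 in two places at once, so the contribution of its urea aryl group cannot be read separately from the change on the benzyl ring.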